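A few compounds are considered here, and "the series" means these few. Any claim that something is new, unique, unknown or untested is made for them only; others in the source may bear on it.

Of the compounds shown here, two of a shared core have been measured in a functional assay on isolated protein for inhibition of Glucose-dependent insulinotropic receptor (Homo sapiens), read by HTRF and cAMP accumulation; on this read-out higher numbers stand for an effect only at larger amounts of compound and lower numbers for an effect already at smaller amounts. Compound 1 `CCC(F)(F)C(=O)N1CCC(Oc2ncnc(Oc3ccc(S(C)(=O)=O)nc3C)c2F)CC1` gives 17.4 nM, and compound 2 `Cc1nc(S(C)(=O)=O)ccc1Oc1ncnc(OC2CCN(C(=O)C3(F)CCC3)CC2)c1F` gives 24.7 nM; the two numbers lie within the scatter of each other, as the step of a 1.4-fold higher number from compound 1 to compound 2 (0.15 log units; within the scatter) shows. Compound 3 `Cc1nc(S(C)(=O)=O)ccc1Oc1ncnc(OC2CCN(C(=O)C3CCCC3)CC2)c1F` differs from compound 2 only by a group of 5 heavy atoms (5 carbon; one five-membered non-aromatic ring of carbon only) in place of a group of 5 heavy atoms (4 carbon, 1 fluorine; one four-membered non-aromatic ring of carbon only), on a carbonyl carbon. Within the data shown here, the single step that bears on this, a 1.4-fold higher number from compound 1 to compound 2 (0.15 log units; within the scatter), also exchanged a group on that carbonyl carbon and stayed within the scatter, so compound 3 is expected to show little change beyond the scatter, a 1.0-fold higher number from compound 2 to compound 3 (0.01 log units; within the scatter), with an estimated value of 25 nM and a range from 10 nM to 60 nM.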

Compound 3, half-maximal effective concentration: 72.8 nM
Compound 3: the middle estimate sits 2.9-fold (0.46 log units) below what was measured, and the stated range ends below it.
By their numbers in this assay, from the lowest: compounds 1 and 2 (each within the scatter of the next); then compound 3.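

The carbonyl carbon is sensitive to which group it carries, even when the group's heavy-atom count stays the same: cyclopentyl gives a 2.9-fold higher number from compound 2 to compound 3 (0.47 log units; beyond the scatter), and a 4.2-fold higher number from compound 1 to compound 3 (0.62 log units; beyond the scatter). Among these three compounds, the two groups that contain fluorine give numbers within the scatter of each other, while cyclopentyl, which has none, stands apart from both. No available evidence explains this shift. Ring size and fluorine change together in the step to compound 3, so their contributions remain inseparable. A cyclobutyl group without fluorine on the same carbonyl carbon could separate them.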